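The source may report more compounds than this note shows. Statements on the series, on what has been measured and on what is new or still open speak of the compounds shown alone.

Measured so far in a functional assay on A549 cells (Homo sapiens) for cytotoxicity, with a stated time of 48 h; a higher number here means a weaker inhibitor, a lower number a stronger inhibitor:
- compound 1 `CC(=O)Oc1ccc2oc(/C=C/[S+](C)[O-])cc(=O)c2c1`: 4100 nM
- compound 2 `Cc1ccc2oc(/C=C/[S+](C)[O-])cc(=O)c2c1`: 1700 nM

Of this pair, compound 2 has the lower number, 1700 nM, which makes it the stronger inhibitor of the two in this assay. The next compound, compound 3 `CCCCOc1ccc2oc(/C=C/[S+](C)[O-])cc(=O)c2c1`, keeps the shared core and changes one group, with butoxy in place of methyl on an aromatic carbon. Within the data shown here, only one measured step bears on this change, at the same aromatic carbon: a 2.4-fold lower number from compound 1 to compound 2 (0.38 log units; beyond the scatter). That step, methyl in place of acetoxy, was modest. A single step reveals little about butoxy, so only a modest change is expected, with no firm direction, and it may well stay within the scatter. The expected step is a 1.2-fold higher number from compound 2 to compound 3 (0.07 log units; within the scatter). Compound 3 is estimated at 2000 nM, with an expected range from 700 nM to 6000 nM.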

Compound 3, half-maximal inhibitory concentration: 1400 nM
Compound 3: the middle estimate sits 1.4-fold (0.15 log units) above what was measured; measured number inside the range.
By their numbers in this assay, from the lowest: compounds 3 and 2 (each within the scatter of the next); then compound 1.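

In this assay, methyl gives way to butoxy, a group of 5 heavy atoms, and the result is a 1.2-fold lower number from compound 2 to compound 3 (0.08 log units; within the scatter), so this aromatic carbon carries the larger group with no change that can be told from the scatter. The comparison with compound 1 keeps the oxygen on the ring and puts butyl in place of acetyl, giving a 2.9-fold lower number from compound 1 to compound 3 (0.47 log units; beyond the scatter), which shows that the group on that oxygen can shift the number beyond the scatter. No measurement here explains either step.

Still open, as far as these compounds go, is whether a longer chain such as hexyloxy would keep the number in this range or move it. An amine or a carboxylic acid on the same aromatic carbon also remains untested in the compounds shown here.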